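This account rests on a few compounds, and the source may have more. Where it says the series, first, only, none or still open, it means among the compounds named here.

Compound 1 `COc1ccc(-c2nnc(SC/C(=N/O)c3ccccc3)n2-c2ccccc2)cc1`: 73%
Compound 2 `C=CCn1c(SC/C(=N/O)c2ccccc2)nnc1-c1ccc(OC)cc1`: 57%
Compound 3 `C=CCn1c(SCC(=O)c2ccccc2)nnc1-c1cc(OC)c(OC)c(OC)c1`: 60%

The three measured compounds were tested in a functional assay on the whole organism (strain albino) for inhibition, with Rattus norvegicus as the target, read by paw edema, with a stated time of 5 h, at a dose of 0.28 mmol/kg by the oral route; a higher number here means more inhibition at the dose given (going by the name of the read-out), a lower number less inhibition. Compound 1 and compound 2 share a core and differ in one place: phenyl in place of allyl on an aromatic nitrogen. This change gave a number 16 percentage points higher from compound 2 to compound 1 (beyond the scatter). Compound 3 gives a number close to that of compound 2, and the difference between the two cores of compound 2 and compound 3 is not broken down here.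

Compound 4 `COc1cc(-c2nnc(SCC(=O)c3ccccc3)n2-c2ccccc2)cc(OC)c1OC` has not yet been measured in this assay. It differs from compound 3 in one place: phenyl in place of allyl on an aromatic nitrogen. Within the data shown here, this is the same kind of change as the one from compound 2 to compound 1, though the surroundings are not identical: in compound 1 the new phenyl sits next to the ring atom that bears a 4-methoxyphenyl group, whereas in compound 4 it sits next to the ring atom that bears a (benzoylmethyl)sulfanyl group. Resting on the step seen from compound 2 to compound 1, a number 16 percentage points higher from compound 2 to compound 1 (beyond the scatter), a step of similar size, a number 14 percentage points higher from compound 3 to compound 4 (beyond the scatter), is expected for compound 4. Compound 4 is therefore estimated at 74%, with a likely range from 60% to 86%.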

Compound 4, a percentage reported as inhibition, in the whole organism at one dose (the size of the read-out at that dose, not a potency): 72%
The estimate for compound 4 lay 2 percentage points above the measured number; measured number inside the range.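

In this assay, phenyl in place of allyl on the aromatic nitrogen gave a number 12 percentage points higher from compound 3 to compound 4 (beyond the scatter), so the change raised the number on the core of compound 3 as it had on the core of compound 1. Among these compounds, the step carried from one core to the other with no size difference that can be told apart: the same change on two cores in this assay, a number 16 percentage points higher (beyond the scatter) from compound 2 to compound 1 and a number 12 percentage points higher (beyond the scatter) from compound 3 to compound 4, 4 percentage points apart, within the scatter of two such steps This agreement rests on only two pairs, read at a single dose and a single time, so it does not establish a rule for other cores and does not show why phenyl gives the higher number.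

The compounds shown leave open how a saturated group, such as an ethyl or a longer alkyl chain, would compare with allyl and phenyl on that aromatic nitrogen. They also leave open whether a phenyl carrying an amine or a carboxylic acid would keep the same step.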